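Fused Indole in Place of a Pyrrolyl-Chlorophenyl Group

The compounds below may be only part of what the source reports. "The series", "measured", "known", "first", "only" and "open" are said of these compounds alone.

Going by the values given here, compound 2 `CN1CCN(CCCS(=O)(=O)c2ccc3nc(NC(=O)NC(=O)c4cc(-n5cccc5)ccc4Cl)sc3c2)CC1` gives 2.6 in a physicochemical assay for lipophilicity (a lower number here means a more polar compound, a higher number a more lipophilic compound), the highest of the two numbers so far; its nearest neighbour, compound 1 `CN1CCN(CCCS(=O)(=O)c2ccc3nc(NC(=O)NC(=O)c4cccc(-n5cccn5)c4Cl)sc3c2)CC1`, gives 1.6, and the only measured step, a number 1.00 log units higher from compound 1 to compound 2 (beyond the scatter), lies beyond the scatter. Compound 3 `CN1CCN(CCCS(=O)(=O)c2ccc3nc(NC(=O)NC(=O)c4cc5c(ccn5C)cc4Cl)sc3c2)CC1` has not yet been measured in this assay. It differs from compound 2 by 5-chloro-1-methyl-1H-indol-6-yl in place of 2-chloro-5-(1H-pyrrol-1-yl)phenyl on a carbonyl carbon. Among the compounds with values here, no measured step covers this exchange: the step from compound 1 to compound 2 swapped one five-membered ring with its position for another, whereas here the five-membered ring becomes fused to the six-membered one and carries a methyl group. With heavy-atom count, acceptor count and charge unchanged, no step beyond the scatter is expected, so no change at the digits printed from compound 2 to compound 3 (within the scatter) is estimated to be small. Compound 3 is therefore expected to give about 2.6, within 2.1 to 3.1.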

Compound 3, distribution coefficient: 2.8
Compound 3: middle estimate off by 0.20 log units, on the low side; low and high end bracket the measured number.
By their numbers in this assay, from the lowest: compound 1; then compounds 2 and 3 (each within the scatter of the next).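

On the carbonyl carbon, 5-chloro-1-methyl-1H-indol-6-yl and 2-chloro-5-(1H-pyrrol-1-yl)phenyl cannot be told apart in this assay, since the exchange gives a number 0.20 log units higher from compound 2 to compound 3 (within the scatter), so a fused ring system serves here as well as the separate pyrrolyl ring. The gap to 2-chloro-3-(1H-pyrazol-1-yl)phenyl persists with the new group, at a number 1.20 log units higher from compound 1 to compound 3 (beyond the scatter), which leaves compound 1 alone at the low end of the three. Nothing measured on these compounds accounts for either result.

The compounds shown leave open whether the methyl group on the indole nitrogen matters, as no indole with a hydrogen or a longer chain there appears among them. They also leave open how this position would read with an amine or a carboxylic acid on the ring.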